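Taking the bromo off a compound at the limit

The source may report more compounds than this note shows. Statements on the series, on what has been measured and on what is new or still open speak of the compounds shown alone.

Three compounds measured in a functional assay on LNCaP cells (Homo sapiens) for cytotoxicity (a lower number here means a stronger inhibitor, a higher number a weaker inhibitor), so far, each value a limit and not a number:
Compound 1 `COc1ccc(Cn2cc(/C=N\NC(=O)c3c[nH]c4ccccc34)c3cc(OC)ccc32)cc1` gives > 100000 nM as a limit
Compound 2 `COc1ccc(Cn2cc(/C=N\NC(=O)c3c[nH]c4ccc(Br)cc34)c3cc(OC)ccc32)cc1` gives > 100000 nM as a limit
Compound 3 `COc1ccc2c(c1)c(/C=N\NC(=O)c1c[nH]c3ccc(Br)cc13)cn2Cc1ccc(Cl)cc1` gives > 100000 nM as a limit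

The set shows the limit of > 100000 nM in this assay, at which 3 of the 3 values shown sit, and no readable number, so compound 3 holds no rank among these compounds. The next compound, compound 4 `COc1ccc2c(c1)c(/C=N\NC(=O)c1c[nH]c3ccccc13)cn2Cc1ccc(Cl)cc1`, has hydrogen in place of bromo on an aromatic carbon, which turns 5-bromo-1H-indol-3-yl into 1H-indol-3-yl. The change hydrogen in place of bromo on an aromatic carbon is small.

Run the other way, the same swap gives a step that the two limits leave unreadable from compound 1 to compound 2 and so shows no size. The other measured change, chloro in place of methoxy, gives a step that the two limits leave unreadable from compound 2 to compound 3 and is just as silent. Compound 1 already carries hydrogen at that place and still gives > 100000 nM as a limit. Neither step points in a direction, so compound 4 is expected to stay near the same limit. What is expected is a number no higher from compound 3 to compound 4 (the limit leaves the size open) with neither direction favoured. For compound 4 the estimated value is 100000 nM with an expected range of 40000 nM to 200000 nM and it will probably be reported only as a limit.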

Compound 4, half-maximal inhibitory concentration: > 100000 nM
Compound 4 was reported as a limit (the forecaster's own chance of this, stated with the estimate: 85%); the middle value sits exactly at the limit.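

Compound 4 gives > 100000 nM, a limit and not a number. The steps to compound 4 from compound 3 and from compound 1 cannot be read, with a limit at both ends. Left open is whether bromo against hydrogen, or chloro against methoxy, changes anything in this assay, and the compounds show only this: the limit of > 100000 nM in this assay, at which 4 of the 4 values shown sit.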